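The compounds below may be only part of what the source reports. "The series", "measured", "known", "first", "only" and "open" are said of these compounds alone.

Measured so far in an ADME assay on cells (Homo sapiens) for cytotoxicity, read by resazurin assay, with a stated time of 5 days; a lower number here means that less compound is tolerated, a higher number that more compound is tolerated:
- compound 1 `COc1ccc(-c2nc(CSc3cccc(Cl)c3)nc3ccsc23)cn1`: > 10000 nM
- compound 2 `COc1ccc(-c2nc(C[S+]([O-])c3cccc(Cl)c3)nc3ccsc23)cn1`: > 50000 nM

Both values are limits, not numbers. Compound 1 is therefore placed only by the limit of > 10000 nM in this assay, at which 1 of the 2 values shown sits, and compound 2 only by the limit of > 50000 nM in this assay, at which 1 of the 2 values shown sits.

Compound 3 `COc1ccc(-c2nc(CSc3cccc(C(F)(F)F)c3)nc3ccsc23)cn1` differs from compound 1 by trifluoromethyl in place of chloro on an aromatic carbon. Among the compounds with values here, the only measured step, a step that the two limits leave unreadable from compound 1 to compound 2, is a different change and gives no usable size. No step beyond the scatter is therefore expected in this assay, and no direction is favoured. The estimated step is a step that the limit leaves unreadable from compound 1 to compound 3. For compound 3 the estimate is 18000 nM, with an expected range of 7000 nM to 50000 nM.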

Compound 3, half-maximal cytotoxic concentration: > 50000 nM
Compound 3: only a limit was reported; the forecaster's own chance of this, stated with the estimate: 80%; middle value at least 2.7-fold (0.44 log units) from the limit.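

The step between compound 1 and compound 3 cannot be read: both values are limits. From the compounds shown here alone, whether trifluoromethyl in place of chloro shifts the tolerated concentration in this assay at all remains open, as does where either compound actually lies.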